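A Benzyl Exchange Followed in an Inhibition Screen

The source may report more compounds than this note shows. Statements on the series, on what has been measured and on what is new or still open speak of the compounds shown alone.

Of the compounds shown here, three have so far been tested in a functional assay on 3T3-L1 cells (Mus musculus) for inhibition, with a stated time of 20 min, tested at 20 uM; a lower number here means less inhibition, a higher number more inhibition at the concentration tested (going by the name of the read-out). Compound 1 `Cc1ccc(S(=O)(=O)N(Cc2cccc(F)c2F)Cc2cn(S(=O)(=O)c3ccc(F)cc3)c3ccccc23)cc1` gives -35% in this assay. Compound 2 `Fc1cccc(CNCc2c[nH]c3ccccc23)c1F` gives -1.7%. Compound 3 `Cc1ccc(S(=O)(=O)N(Cc2cn(Cc3ccccc3Cl)nn2)Cc2cn(S(=O)(=O)c3ccc(C)cc3)c3ccccc23)cc1` gives -4.8%. Among these three numbers compound 3 stands second highest: its nearest neighbour is compound 2, whose number lies within the usual scatter of its own, and its furthest is compound 1, whose number lies beyond the scatter and well below.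

Compound 4 `COc1ccc(Cn2cc(CN(Cc3cn(S(=O)(=O)c4ccc(C)cc4)c4ccccc34)S(=O)(=O)c3ccc(C)cc3)nn2)c(OC)c1` differs from compound 3 in a single place: 2,4-dimethoxyphenyl in place of 2-chlorophenyl on a saturated chain carbon bound to an aromatic nitrogen. Among the compounds with values here, no pair of measured compounds shows a step of this kind, so nothing measured here tells how the exchange of one benzyl group for another moves the read-out. On that basis the step from compound 3 to compound 4 is expected to be a number 1.8 percentage points higher from compound 3 to compound 4 (within the scatter), none beyond the scatter. Compound 4 is therefore estimated at -3%, with a range from -22% to 14%.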

Compound 4, a percentage reported as inhibition, at one concentration (the size of the read-out at that concentration, not a potency): 7.6%
For compound 4 the middle estimate is 10.6 percentage points below the measured one, and the stated range covers the measured number.
By their numbers in this assay, from the lowest: compound 1; then compounds 3, 2 and 4 (each within the scatter of the next, the first and the last beyond it).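

In this assay, within the data shown here, the exchange of 2-chlorobenzyl for 2,4-dimethoxybenzyl gives the first readable step at this position, a number 12.4 percentage points higher from compound 3 to compound 4 (beyond the scatter), so the read-out does respond to a change on a saturated chain carbon bound to an aromatic nitrogen. The pair cannot separate the departure of the chlorine from the arrival of the two methoxy groups, since both happen in the same step, and the entering group also has 10 heavy atoms and 2 hydrogen-bond acceptors against 7 and 0. Nothing available accounts for the size or direction of this step.

On these data alone, it remains open whether an unsubstituted benzyl group or a benzyl group carrying a single methoxy would fall with compound 3 or compound 4. As far as these compounds go, it is equally open how a benzyl group bearing a carboxylic acid or an amine would read at this position.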